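The compounds below may be only part of what the source reports. "The series", "measured", "known", "first", "only" and "open" are said of these compounds alone.

Compound 1, `C[C@H](NC(=O)[C@@]1(Cc2ccccc2)CCN1C(=O)OCc1ccccc1)C(=O)N(C)C`: in an ADME assay on HELF cells (Homo sapiens) for cytotoxicity, with a stated time of 3 days (on this read-out higher numbers stand for lower toxicity in this test and lower numbers for higher toxicity in this test), compound 1 gives > 100000 nM, which is a limit of the assay.
Compound 2, `CC(C)[C@H](NC(=O)[C@@]1(Cc2ccccc2)CCN1C(=O)OCc1ccccc1)C(N)=O`: in this assay compound 2 gives > 100000 nM, which is again a limit.

Among the measured compounds shown here, compound 2 therefore stands at the limit of this assay, and so does the only other compound measured; on these numbers it is neither more nor less toxic than compound 1. For the measured compounds named here, the one step between the measured compounds, a step that the two limits leave unreadable from compound 1 to compound 2, cannot be read because of the limit of > 100000 nM in this assay, at which 2 of the 2 values shown sit.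

Compound 3 is `C[C@H](NC(=O)[C@@]1(Cc2ccccc2)CCN1C(=O)OCc1ccccc1)C(=O)NC1CCCCC1`. Relative to compound 2 the change is 1-(cyclohexylcarbamoyl)ethyl in place of 1-carbamoyl-2-methylpropyl on an amide-type nitrogen, an exchange on the side chain of the amide-type nitrogen while the shared core is kept.

The step from compound 1 to compound 2 is the only measured one that bears on this exchange, and its size is not readable. Going by the values given here, no measured step gives a direction for this assay here. Compound 3 is therefore expected to sit where both measured compounds sit, with a step that the limit leaves unreadable from compound 2 to compound 3 expected to show no step beyond the scatter. The estimate for compound 3 in this assay is 150000 nM, within 40000 nM to 500000 nM.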

Compound 3, minimum cytotoxic concentration: 100000 nM
The estimate for compound 3 lay 1.5-fold (0.18 log units) above the measured number; measured number inside the range.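

In this assay compound 3 gives 100000 nM, a number rather than a limit, and so the first reading among these compounds that is not a limit. With 1-(cyclohexylcarbamoyl)ethyl on the amide-type nitrogen, the read-out therefore reaches a number, but the sizes of both new steps cannot be read: the first is a number no higher from compound 2 to compound 3 (the limit leaves the size open), and the second is a number no higher from compound 1 to compound 3 (the limit leaves the size open). Neither step shows that the cyclohexylamino group changes toxicity by any measurable amount, and the other two compounds still rest on one edge of the read-out: the limit of > 100000 nM in this assay, at which 2 of the 3 values shown sit.

On these data alone, whether compound 3 truly differs from compound 1 or compound 2 in this assay stays open, as does whether the number for compound 3 reflects the ring, the larger side chain or neither. As far as these compounds go, it is also open what a benzylamino or morpholino group, or a longer open carbon chain on the amine, would give in place of cyclohexylamino on a carbonyl carbon.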